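Furan for Thiophene on the Exocyclic Double Bond

The source may hold more compounds than are shown below. What is called first, only, known or untested is meant among the compounds shown, and "the series" means these compounds.

Measured compounds:
Compound 1, `CC(=O)OC[C@H]1O[C@@H](n2cc(CN3C(=O)/C(=C\c4ccccc4)c4ccccc43)nn2)[C@H](OC(C)=O)[C@@H](OC(C)=O)[C@@H]1OC(C)=O`: 33300 nM
Compound 2, `CC(=O)OC[C@H]1O[C@@H](n2cc(CN3C(=O)/C(=C\c4cccs4)c4ccccc43)nn2)[C@H](OC(C)=O)[C@@H](OC(C)=O)[C@@H]1OC(C)=O`: > 100000 nM

Both compounds share a peracetylated sugar linked through a triazole to the oxindole-type core drawn above; they differ only in the aromatic group on the exocyclic double bond. In a functional assay on HeLa cells (Homo sapiens) for cytotoxicity, read by sulforhodamine B assay, with a stated time of 48 h (on this read-out higher numbers stand for weaker inhibition and lower numbers for stronger inhibition), compound 1 gives 33300 nM. The value of compound 2 in this assay is a limit of the assay and not a number. The step of an at least 3.0-fold higher number from compound 1 to compound 2 (0.47 log units; beyond the scatter) is therefore open-ended, because the limit of > 100000 nM in this assay, at which 1 of the 2 values shown sits, is where compound 2 sits.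

Compound 3, `CC(=O)OC[C@H]1O[C@@H](n2cc(CN3C(=O)/C(=C\c4ccco4)c4ccccc43)nn2)[C@H](OC(C)=O)[C@@H](OC(C)=O)[C@@H]1OC(C)=O`, carries furan-2-yl in place of thiophen-2-yl on a double-bonded chain carbon bound to a double-bonded ring carbon. For the measured compounds named here, no measured step here swaps one five-membered heteroaromatic ring for another, so the only guidance is that compound 2, the closest neighbour, already sits at the limit. The expected change is therefore none beyond the scatter, expressed as an expected at least 1.1-fold lower number from compound 2 to compound 3 (0.04 log units; that floor lies within the scatter). Compound 3 is thus estimated at 90000 nM, with a range from 30000 nM to 300000 nM, and a fair chance that this assay again reports only a limit.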

Compound 3, half-maximal inhibitory concentration: > 100000 nM
Compound 3 ended at the assay's limit (the forecaster's own chance of this, stated with the estimate: 55%); middle value at least 1.1-fold (0.04 log units) away from the limit.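

In this assay compound 3 gives > 100000 nM as a limit of the assay and not a number. Furan-2-yl in place of phenyl on a double-bonded chain carbon bound to a double-bonded ring carbon gives an at least 3.0-fold higher number from compound 1 to compound 3 (0.47 log units; beyond the scatter) and so joins thiophen-2-yl: both five-membered aromatic rings with one hetero atom now give a higher number than phenyl, and the sulfur of thiophen-2-yl is not needed for this outcome, since a ring with oxygen in its place does the same. The step between the two five-membered rings themselves cannot be read, because both values are limits and no size can be drawn from them: the limit of > 100000 nM in this assay, at which 2 of the 3 values shown sit.

As far as these compounds go, how far either ring lies past that limit stays open, so thiophen-2-yl and furan-2-yl cannot be put in any order. Also open, from the compounds shown here alone, is what a pyridin-2-yl ring, or a phenyl carrying a methoxy group or an amine, would do on this same carbon, and whether any of these would give a lower number than the plain phenyl of the first compound, compound 1.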